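Three Measured Analogues and One Ethyl Substitution to Come

A few compounds are considered here, and "the series" means these few. Any claim that something is new, unique, unknown or untested is made for them only; others in the source may bear on it.

Measured in a functional assay on the whole organism (strain albino) for inhibition, with Rattus norvegicus as the target, read by paw edema, with a stated time of 4 h, at a dose of 0.029 mmol/kg by the oral route; a higher number here means more inhibition at the dose given (going by the name of the read-out), a lower number less inhibition:
compound 1, `C/N=c1/c(C#N)c2n(c(=O)n1-c1ccccc1)CCC2`: 34.8%
compound 2, `CC/N=c1/c(C#N)c2n(c(=O)n1-c1ccccc1)CCC2`: 30.4%
compound 3, `N#Cc1c2n(c(=O)n(-c3ccccc3)/c1=N\CCO)CCC2`: 27.3%

Compound 3 stands at the lowest of these three numbers, but only by small margins: one step is a number 3.1 percentage points lower from compound 2 to compound 3 (within the scatter), and the other is a number 7.5 percentage points lower from compound 1 to compound 3 (within the scatter), so all three compounds read alike within the usual scatter of this assay.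

The next compound, compound 4, `CCCC/N=c1/c(C#N)c2n(c(=O)n1-c1ccccc1)CCC2`, is obtained from compound 3 by the change (ethyl in place of hydroxy on a saturated chain carbon, two bonds along the chain from a double-bonded nitrogen). Going by the values given here, two measured steps bear on this. The step of a number 3.1 percentage points lower from compound 2 to compound 3 (within the scatter) is the same position being altered in the opposite sense, hydroxy taken up where compound 4 instead gives it up. The step of a number 4.4 percentage points lower from compound 1 to compound 2 (within the scatter) shows what adding a small alkyl group to this chain did. Both were within the scatter, so neither hints at a shift that would exceed it.

Compound 4 is therefore expected to stay close to the other three, with an estimate of 30%, ranging between 18% and 42%. The expected step from compound 3 is a number 2.7 percentage points higher from compound 3 to compound 4 (within the scatter), a change not expected to rise beyond the scatter.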

Compound 4, a percentage reported as inhibition, in the whole organism at one dose (the size of the read-out at that dose, not a potency): 22.4%
The estimate for compound 4 lay 7.6 percentage points above the measured number; the measured number falls inside the stated range.
By their numbers in this assay, from the lowest: compounds 4, 3, 2 and 1 (each within the scatter of the next, the first and the last beyond it).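

In this assay, ethyl in place of hydroxy on a saturated chain carbon, two bonds along the chain from a double-bonded nitrogen, gives a small step (a number 4.9 percentage points lower from compound 3 to compound 4 (within the scatter)), and ethyl in place of hydrogen at that same carbon also stays inside the usual spread (a number 8 percentage points lower from compound 2 to compound 4 (within the scatter)). Going by these compounds alone, the new information comes from comparing the two ends of the series: propyl in place of hydrogen on the saturated chain carbon bound to a double-bonded nitrogen gives a number 12.4 percentage points lower from compound 1 to compound 4 (beyond the scatter), the first step in this set to clear the scatter, though only modestly. So the butyl chain of compound 4 is separated from the methyl of compound 1 by a real, if modest, difference that no single smaller step could show, but nothing available here explains that difference.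

The compounds shown leave open whether a chain longer than butyl, or an amine or a carboxylic acid in place of the hydroxy, would follow the same course. They also leave open whether the gap between compound 1 and compound 4 would persist at other doses or read-out times.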